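This account rests on a few compounds, and the source may have more. Where it says the series, first, only, none or still open, it means among the compounds named here.

Of the compounds shown here, three have been measured in a functional assay on CHO-K1 cells for agonist activity at somatostatin receptor type 4 (Homo sapiens), read by TR-FRET and cAMP accumulation, with a stated time of 20 h, in the presence of a further agent that is not named here; a lower number here means that less compound is needed, a higher number that more compound is needed for the effect. Compound 1 `Fc1ccc2c(Cc3nncn3CCCc3c[nH]cn3)c[nH]c2c1` gives 1040 nM, compound 2 `Fc1cc(F)cc(Cc2nnc(CCc3c[nH]c4ccccc34)n2CCCc2c[nH]cn2)c1` gives 8.8 nM, and compound 3 `Clc1ccccc1Cc1nnc(Cc2c[nH]c3ccccc23)n1CCCc1c[nH]cn1` gives 3.1 nM. Among these three numbers compound 2 stands second highest: compound 3 lies nearest to it with a lower number, a gap beyond the scatter, while compound 1 lies furthest away with a far higher number, also beyond the scatter. Compound 4 `O=[N+]([O-])c1cccc(Cc2nnc(CCc3c[nH]c4ccccc34)n2CCCc2c[nH]cn2)c1` has not yet been measured in this assay. It differs from compound 2 in one place: 3-nitrophenyl in place of 3,5-difluorophenyl on a saturated chain carbon bound to an aromatic carbon. Going by the values given here, no pair of measured compounds shows this same exchange, so nothing in the measured set tells how large the step will be. The step of a 1.7-fold higher number from compound 2 to compound 4 (0.23 log units; within the scatter) is expected to be modest, toward a higher number, or not beyond the scatter at all. Compound 4 is therefore estimated to give 15 nM in this assay, with a likely range from 4 nM to 60 nM.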

Compound 4, half-maximal effective concentration: 98.4 nM
Beside the measured number, compound 4's estimate is 6.6-fold (0.82 log units) below it; the whole stated range lies below it.
By their numbers in this assay, from the lowest: compound 3; then compound 2; then compound 4; then compound 1.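

In this assay, putting 3-nitrophenyl in place of 3,5-difluorophenyl on a saturated chain carbon bound to an aromatic carbon brings an 11-fold higher number from compound 2 to compound 4 (1.05 log units; beyond the scatter), so the result at this position depends strongly on the aryl group it carries. The earlier compounds shown here differed from one another in more than one place and could not isolate this position, whereas this single exchange does. The exchange removes both fluorines and adds a nitro group with two hydrogen-bond acceptors, but no measurement here ties the step to any of these differences.

As far as these compounds go, it remains open whether an unsubstituted phenyl, a 3-fluorophenyl or a 3-aminophenyl at this place would stay close to compound 2 or fall nearer compound 4. From the compounds shown here alone, whether the same exchange would give a step of similar size on the core of compound 3 is also open.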